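Trimming the alkyl substituent on the shared core

A few compounds are considered here, and "the series" means these few. Any claim that something is new, unique, unknown or untested is made for them only; others in the source may bear on it.

Measured so far in an assay on CHO cells for displacement of a labelled ligand from adenosine receptor A1 (Homo sapiens); a higher number here means a weaker inhibitor, a lower number a stronger inhibitor:
compound 1 `c1ccc(-c2cc(-c3ccccc3)c3nc[nH]c3n2)cc1`: 1.2 nM
compound 2 `CCC(CC)c1nc2c(-c3ccccc3)cc(-c3ccccc3)nc2[nH]1`: 0.87 nM
compound 3 `CC(C)Cc1nc2c(-c3ccccc3)cc(-c3ccccc3)nc2[nH]1`: 0.55 nM

Among the measured compounds shown here, compound 3 gives the lowest number of the three; its step from compound 2 lies within the scatter, a 1.6-fold lower number from compound 2 to compound 3 (0.20 log units; within the scatter), and only the step of a 2.2-fold lower number from compound 1 to compound 3 (0.34 log units; beyond the scatter) is modest and beyond it. Compound 4 `Cc1nc2c(-c3ccccc3)cc(-c3ccccc3)nc2[nH]1` differs from compound 3 by hydrogen in place of isopropyl on a saturated chain carbon bound to an aromatic carbon; read one bond further out, isobutyl becomes methyl. For the measured compounds named here, the steps that bear on this are a 1.4-fold lower number from compound 1 to compound 2 (0.14 log units; within the scatter) and a 2.2-fold lower number from compound 1 to compound 3 (0.34 log units; beyond the scatter): adding a branched alkyl in place of hydrogen lowered the number a little, so removing most of it should move the number back toward that of compound 1. The expected step is a 1.6-fold higher number from compound 3 to compound 4 (0.21 log units; within the scatter), small. Compound 4 is therefore estimated at 0.9 nM, with a range of 0.4 nM to 2 nM.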

Compound 4, inhibition constant: 14 nM
Beside the measured number, compound 4's estimate is 16-fold (1.19 log units) below it, outside the stated range (above it).
By their numbers in this assay, from the lowest: compounds 3, 2 and 1 (each within the scatter of the next, the first and the last beyond it); then compound 4.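

Cutting isobutyl back to methyl gives a 25-fold higher number from compound 3 to compound 4 (1.41 log units; beyond the scatter), and methyl in place of pentan-3-yl gives a 16-fold higher number from compound 2 to compound 4 (1.21 log units; beyond the scatter). Methyl in place of hydrogen also gives a 12-fold higher number from compound 1 to compound 4 (1.07 log units; beyond the scatter), so at this position the number does not track chain size: methyl reads higher than hydrogen, isobutyl and pentan-3-yl alike. Nothing available accounts for this reversal.

Open, going by these compounds, is where the number falls again between methyl and isobutyl, for instance with ethyl or a propyl chain. Also open, on these data alone, is how a chain ending in an amine or a carboxylic acid would read in this assay.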